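The source may hold more compounds than are shown below. What is called first, only, known or untested is meant among the compounds shown, and "the series" means these compounds.

Series notes. Compound 1 `Cc1nc(C(F)(F)F)ccc1C(=O)Nc1ccc(Cl)c(-c2nc3ccccc3[nH]2)c1` and compound 2 `Cc1nc(C(F)(F)F)ccc1C(=O)Nc1ccc(Cl)c(-c2nc3ccccc3n2C)c1` carry a 1H-benzimidazol-2-yl group on the shared core; in an assay on C3H 10T1/2 cells for inhibition of Sonic hedgehog protein (Mus musculus), read by a luciferase reporter (a lower number here means a stronger inhibitor, a higher number a weaker inhibitor), compound 1 gives 12 nM and compound 2 gives 9 nM, and a 1.3-fold lower number from compound 1 to compound 2 (0.12 log units; within the scatter). Compound 3 `Cc1nc(C(F)(F)F)ccc1C(=O)Nc1ccc(Cl)c(-n2cc3ccccc3n2)c1` gives 80 nM in this assay, the highest of the three numbers; the steps of a 6.7-fold higher number from compound 1 to compound 3 (0.82 log units; beyond the scatter) and an 8.9-fold higher number from compound 2 to compound 3 (0.95 log units; beyond the scatter) both lie beyond the scatter. Compound 4 `Cc1nc(C(F)(F)F)ccc1C(=O)Nc1ccc(Cl)c(-c2cccnc2)c1` differs from compound 3 by pyridin-3-yl in place of 2H-indazol-2-yl on an aromatic carbon. Among the measured compounds shown here, no measured step swaps a group of two rings for a single ring, so the two steps ending at compound 3 bear only indirectly; they show that changing this group has moved the number modestly. For compound 4 a modest further rise is expected, a 1.9-fold higher number from compound 3 to compound 4 (0.27 log units; within the scatter), giving an estimate of 150 nM with a range of 40 nM to 600 nM.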

Compound 4, half-maximal inhibitory concentration: 10000 nM
Compound 4: the middle estimate sits 67-fold (1.82 log units) below what was measured; the whole stated range lies below it.
By their numbers in this assay, from the lowest: compounds 2 and 1 (each within the scatter of the next); then compound 3; then compound 4.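

Going to the single ring pyridin-3-yl gives a 130-fold higher number from compound 3 to compound 4 (2.10 log units; beyond the scatter) and also a 1100-fold higher number from compound 2 to compound 4 (3.05 log units; beyond the scatter) and an 830-fold higher number from compound 1 to compound 4 (2.92 log units; beyond the scatter) at this position, far larger than any step among the two-ring groups of compounds 1, 2 and 3. In this assay this position therefore separates these two-ring groups from this single ring much more sharply than it separates them from each other. Nothing at hand gives a reason for the rise. As far as these compounds go, whether a phenyl group, or pyridin-3-yl carrying an amine, would bring the number back down stays open.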